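The compounds below may be only part of what the source reports. "The series", "measured", "known", "first", "only" and "open" are said of these compounds alone.

Measured compounds:
compound 1, `FC1(Cc2ccccc2)CCN(CCCc2c[nH]c3ccc(-n4cnnc4)cc23)CC1`, 66 nM in a functional assay on CHO cells for agonist activity at 5-hydroxytryptamine receptor 1B (Homo sapiens), read by GTPgammaS binding; a lower number here means that less compound is needed, a higher number that more compound is needed for the effect
compound 2, `FC1(Cc2ccccc2C(F)(F)F)CCN(CCCc2c[nH]c3ccc(-n4cnnc4)cc23)CC1`, 290 nM in this assay

Among the compounds with values here, of the two compounds measured, compound 2 gives the higher number: in this assay compound 2 gives 290 nM, while compound 1 gives 66 nM, and the only measured step, a 4.4-fold higher number from compound 1 to compound 2 (0.64 log units; beyond the scatter), is the change that separates them. Compound 3, `Fc1cccc(CCC2(F)CCN(CCCc3c[nH]c4ccc(-n5cnnc5)cc34)CC2)c1`, has not yet been measured in this assay. It differs from compound 2 by 3-fluorobenzyl in place of 2-(trifluoromethyl)phenyl on a saturated chain carbon bound to a saturated ring carbon. The change removes the trifluoromethyl whose addition gave the step of a 4.4-fold higher number from compound 1 to compound 2 (0.64 log units; beyond the scatter), so that part of the change argues for the number moving back toward that of compound 1. The second part, the move from 2-(trifluoromethyl)benzyl to 2-(3-fluorophenyl)ethyl, has no measured counterpart among the compounds, and nothing shown tells how the fluorine or the longer link would change the number. Weighing the one measured step against that unknown, the number for compound 3 is expected to fall by about a 2.6-fold lower number from compound 2 to compound 3 (0.42 log units; beyond the scatter). Compound 3 is therefore estimated at 110 nM, in a range from 35 nM to 400 nM.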

Compound 3, half-maximal effective concentration: 440 nM
Estimate against measurement, compound 3: 4.0-fold (0.60 log units) below; the whole stated range lies below it.
By their numbers in this assay, from the lowest: compound 1; then compounds 2 and 3 (each within the scatter of the next).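

In this assay, putting 2-(3-fluorophenyl)ethyl in place of 2-(trifluoromethyl)benzyl gives a 1.5-fold higher number from compound 2 to compound 3 (0.18 log units; within the scatter), so the two groups cannot be told apart at this position, and a compound without the trifluoromethyl does not return toward compound 1. Measured against the plain benzyl group of compound 1, the 2-(3-fluorophenyl)ethyl group gives a 6.7-fold higher number from compound 1 to compound 3 (0.82 log units; beyond the scatter), which stands alongside a 4.4-fold higher number from compound 1 to compound 2 (0.64 log units; beyond the scatter) as a second change at this position that lies beyond the scatter and goes the same way, leaving compound 1 with the lowest number of the three. Nothing available explains this shared direction.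

The compounds shown leave open whether the fluorine or the longer link carries the difference between compound 1 and compound 3, since both change together; a plain 2-phenylethyl group and a 3-fluorobenzyl group would separate the two. They also leave open whether any group at this position could give a lower number than compound 1, for instance a methoxy or a hydroxyl on the benzyl ring, or an amine in place of the phenyl.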